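Replacing an Acid Ether with an Acrylamide

The compounds below may be only part of what the source reports. "The series", "measured", "known", "first", "only" and "open" are said of these compounds alone.

Compound 1 `O=C(O)COc1ccncc1-c1ccc2ccccc2c1` was entered into an assay on a protein complex for inhibition of CDK8/Cyclin C (Homo sapiens), with a stated time of 1 h (a lower number here means a stronger inhibitor, a higher number a weaker inhibitor), yet for compound 1 the outcome stands as "not determined" (no result reported), so no number describes where it sits. Among the measured compounds shown here, the only measured value comes from compound 2 `Cn1ncc2cc(-c3cnccc3/C=C/C(=O)N3CCOCC3)ccc21`, which in this assay gives 356 nM. For the measured compounds named here, compound 2 is built differently from compound 1 in more than one place, so no single step connects them, and its value can serve only as a rough anchor.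

Compound 3 `O=C(/C=C/c1ccncc1-c1ccc2ccccc2c1)NC1CC1` differs from compound 1 in one place: 2-(cyclopropylcarbamoyl)ethenyl in place of carboxymethoxy on an aromatic carbon. From the compounds shown here alone, compound 1 has no number, and a computed step to compound 3 does not exist, so whether this change raises or lowers the reading in this assay beyond the usual scatter, or leaves it unchanged, stays open. Going by the values given here, compound 3 shares with compound 2 an ethenyl-linked amide on an aromatic ring, and the value of compound 2, 356 nM, is the only guide at hand. Compound 3 is expected to give about 800 nM in this assay, with a range from 200 nM to 4000 nM.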

Compound 3, half-maximal inhibitory concentration: 40.1 nM
Estimate against measurement, compound 3: 20-fold (1.30 log units) above; the measured number lies below the stated range.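

Among the compounds shown here, compound 1 has no number in this assay, so the reading of compound 3, 40.1 nM, cannot be set against it and no step between compound 1 and compound 3 can be read. From the compounds shown here alone, what putting 2-(cyclopropylcarbamoyl)ethenyl in place of carboxymethoxy does to the reading therefore stays open. No supporting measurement bears on this result.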